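This account rests on a few compounds, and the source may have more. Where it says the series, first, only, none or still open, it means among the compounds named here.

Of the compounds shown here, three of one series have been measured in a functional assay (strain AB) with Danio rerio as the target, read by microscopy, with a stated time of 1 h; on this read-out higher numbers stand for an effect only at larger amounts of compound and lower numbers for an effect already at smaller amounts. Compound 1 `CC(C)(C)OC(=O)CCCC[N+]1(C)CCc2c(sc(NC(=O)Nc3ccc(Cl)cc3)c2C(N)=O)C1` gives 140 nM in this assay. Compound 2 `CC(C)(C)OC(=O)CCC[N+]1(C)CCc2c(sc(NC(=O)Nc3ccc(Cl)cc3)c2C(N)=O)C1` gives 250 nM in this assay, and compound 3 `CC(C)(C)OC(=O)CCCCN1CCc2c(sc(NC(=O)Nc3ccc(Cl)cc3)c2C(N)=O)C1` gives 710 nM in this assay, the highest number of the three, beyond the scatter against both of the others. The difference between the core of compound 2 and the core of compound 3 is not broken down here.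

Compound 2 and compound 1 differ in one place: (tert-butoxycarbonyl)methyl in place of tert-butoxycarbonyl on a saturated chain carbon, three bonds along the chain from an amine nitrogen in a ring. This change made a step of a 1.8-fold lower number from compound 2 to compound 1 (0.25 log units; within the scatter).

Compound 4 `CC(C)(C)OC(=O)CCCCCN1CCc2c(sc(NC(=O)Nc3ccc(Cl)cc3)c2C(N)=O)C1` has not yet been measured in this assay. It differs from compound 3 in one place: (tert-butoxycarbonyl)methyl in place of tert-butoxycarbonyl on a saturated chain carbon, four bonds along the chain from an amine nitrogen in a ring. This is the same kind of change as that from compound 2 to compound 1, but not the same: in compound 2 and compound 1 the place is three bonds along the chain from an amine nitrogen in a ring, whereas in compound 3 and compound 4 it is four bonds along the chain from an amine nitrogen in a ring, and the two pairs also sit on cores whose difference is not broken down here.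

Going by the values given here, since the one measured instance of this kind of change gave a 1.8-fold lower number from compound 2 to compound 1 (0.25 log units; within the scatter), a step within the scatter, the change is expected to make a similarly modest step here, estimated at a 1.6-fold lower number from compound 3 to compound 4 (0.20 log units; within the scatter). Among the compounds with values here, with only one precedent and a different core, the range is kept wide. Compound 4 is therefore expected to give about 450 nM in this assay, with an estimated span from 200 nM to 1100 nM.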

Compound 4, half-maximal effective concentration: 620 nM
Compound 4: the middle estimate sits 1.4-fold (0.14 log units) below what was measured, and the stated range covers the measured number.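

In this assay the new step is a 1.1-fold lower number from compound 3 to compound 4 (0.06 log units; within the scatter), so passing from tert-butoxycarbonyl to (tert-butoxycarbonyl)methyl at this place leaves the number of the parent compound unchanged within the scatter. Set beside the step on the other core, the change reads the same on both, and no dependence on the core can be seen: the same change on two cores in this assay, a 1.8-fold lower number (0.25 log units; within the scatter) from compound 2 to compound 1 and a 1.1-fold lower number (0.06 log units; within the scatter) from compound 3 to compound 4, 1.6-fold (0.19 log units) apart, within the scatter of two such steps. This shows that, in these two pairs, the change carries from one core to the other without a step beyond the scatter on either, but it does not show that the change has a real effect of its own, that its direction is settled, or that the same would hold on any further core, since two small steps in one assay cannot support that.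

The compounds shown leave open how a longer chain would read on either core, since the extension is seen only at these two places along the chain. They also leave open what a carboxylic acid or an amide in place of the tert-butyl ester would do at the end of the chain, and whether a bromine in place of the chlorine would alter the picture.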